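The source may report more compounds than this note shows. Statements on the series, on what has been measured and on what is new or still open speak of the compounds shown alone.

Measured in a functional assay on MCF7 cells (Homo sapiens) for cytotoxicity, read by MTT assay, with a stated time of 48 h; a higher number here means a weaker inhibitor, a lower number a stronger inhibitor:
- compound 1 `COc1ccc(/C=C2/S/C(=N/c3ccccc3)N(Cc3ccncc3)C2=O)cc1`: 31500 nM
- compound 2 `O=C1/C(=C\c2ccc([N+](=O)[O-])cc2)S/C(=N/c2ccccc2)N1Cc1ccncc1`: 13000 nM

Of these two, compound 2 has the lower number, and the gap is a 2.4-fold lower number from compound 1 to compound 2 (0.38 log units; beyond the scatter). That modest step, nitro in place of methoxy on an aromatic carbon, is the only measured one bearing on the next change.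

Compound 3 `O=C1/C(=C\c2ccc(O)c(O)c2)S/C(=N/c2ccccc2)N1Cc1ccncc1` carries 3,4-dihydroxyphenyl in place of 4-nitrophenyl on a double-bonded chain carbon bound to a double-bonded ring carbon. Going by the values given here, no measured compound carries this group, so only a small rise in this assay, not clearly beyond the scatter, is expected: a 1.5-fold higher number from compound 2 to compound 3 (0.19 log units; within the scatter). For compound 3 the estimated value is 20000 nM, with an expected range of 6000 nM to 60000 nM.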

Compound 3, half-maximal inhibitory concentration: 12400 nM
Beside the measured number, compound 3's estimate is 1.6-fold (0.21 log units) above it, and the stated range covers the measured number.
By their numbers in this assay, from the lowest: compounds 3 and 2 (each within the scatter of the next); then compound 1.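

Swapping 4-nitrophenyl for 3,4-dihydroxyphenyl on a double-bonded chain carbon bound to a double-bonded ring carbon gives a 1.0-fold lower number from compound 2 to compound 3 (0.02 log units; within the scatter) in this assay, so these two groups cannot be told apart here. Going by these compounds alone, replacing 4-methoxyphenyl with 3,4-dihydroxyphenyl at this place gives a 2.5-fold lower number from compound 1 to compound 3 (0.40 log units; beyond the scatter) in this assay, so 4-methoxyphenyl is now the only group of the three that stands apart. No evidence at hand accounts for these results.

On these data alone, whether an amine or a carboxylic acid on the phenyl ring at this place would match compound 3 or fall outside its range stays open. As far as these compounds go, whether a single hydroxyl would do the same as the two in compound 3 also stays open.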